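The source may report more compounds than this note shows. Statements on the series, on what has been measured and on what is new or still open speak of the compounds shown alone.

Measured in an ADME assay on BJ cells (Homo sapiens) for antiproliferative activity, read by MTT assay, with a stated time of 72 h; a higher number here means a weaker inhibitor, a lower number a stronger inhibitor:
compound 1 `O=c1[nH]c(=O)n(CCC(CO)CO)cc1-c1ccco1`, 500 nM
compound 2 `CC(=O)OCC(CCn1cc(C#Cc2cc(F)cc(F)c2)c(=O)n(C(=O)c2ccccc2)c1=O)COC(C)=O`, 46600 nM
compound 3 `O=c1[nH]c(=O)n(CCC(CO)CO)cc1C#Cc1cc(F)cc(F)c1`, > 100000 nM (a limit)

In this assay compound 3 returns only a limit, > 100000 nM, the point described by the limit of > 100000 nM in this assay, at which 1 of the 3 values shown sits, so no number is known for it. Compound 1 gives 500 nM, and compound 2 gives 46600 nM.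

Compound 4 `O=c1[nH]c(=O)n(CCC(CO)CO)cc1C#Cc1ccc(Br)cc1` differs from compound 3 by 4-bromophenyl in place of 3,5-difluorophenyl on a triple-bonded carbon, in words 4-bromophenyl in place of 3,5-difluorophenyl on a triple-bonded carbon. Among the compounds with values here, no measured pair differing in one place is available, so the size of this step cannot be taken from the data. With compound 3 standing at the limit, the step from compound 3 to compound 4 is expected to be none beyond the scatter, a number no higher from compound 3 to compound 4 (the limit leaves the size open), and a limit may again be all that is reported. Compound 4 is therefore estimated at 100000 nM, between 30000 nM and 300000 nM.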

Compound 4, half-maximal inhibitory concentration: > 100000 nM
Compound 4: no number, only a limit; the forecaster's own chance of this, stated with the estimate: 60%; the middle value sits exactly at the limit.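

Compound 3 and compound 4 both return only a limit in this assay, so no step between them can be read: the limit of > 100000 nM in this assay, at which 2 of the 4 values shown sit.

The compounds shown leave open whether 3,5-difluorophenyl and 4-bromophenyl on a triple-bonded carbon differ at all in this read-out.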